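The source may hold more compounds than are shown below. What is called first, only, known or untested is meant among the compounds shown, and "the series" means these compounds.

Working notes on the series in a functional assay on HL-60 cells (Homo sapiens) for cytotoxicity, read by ELISA, with a stated time of 2 days; a higher number here means a weaker inhibitor, a lower number a stronger inhibitor:

- compound 1 `Oc1cccc(-c2cc(-c3ccccc3)nc(-c3cccs3)c2)c1`: 18900 nM
- compound 2 `Oc1cccc(-c2cc(-c3ccccc3)nc(-c3ccco3)c2)c1`: 24000 nM
- compound 3 `Oc1cccc(-c2cc(-c3ccccc3)nc(-c3ccccn3)c2)c1`: 15100 nM

Compound 3, at 15100 nM, has no separate rank in this assay, since its value lies within the scatter of the other two. Compound 4 `Oc1cccc(-c2cc(-c3ccccc3)nc(-c3cccnc3)c2)c1` is not yet measured. It carries pyridin-3-yl in place of pyridin-2-yl on an aromatic carbon.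

Among the compounds with values here, no measured step makes this exact exchange, so the evidence is indirect. The nearest steps are the other swaps of the same aromatic group: a 1.3-fold lower number from compound 1 to compound 3 (0.10 log units; within the scatter), a 1.6-fold lower number from compound 2 to compound 3 (0.20 log units; within the scatter) and a 1.3-fold higher number from compound 1 to compound 2 (0.10 log units; within the scatter). All three stay within the scatter, so thiophen-2-yl, furan-2-yl and pyridin-2-yl cannot be told apart at this position on these three compounds. As far as these compounds go, whether that tolerance extends to pyridin-3-yl is untested, which leaves some width on the expectation.

The expected result is a 1.2-fold higher number from compound 3 to compound 4 (0.08 log units; within the scatter), with no shift beyond the scatter and no firm direction. For compound 4 the estimated value is 18000 nM, with an expected range of 9000 nM to 36000 nM.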

Compound 4, half-maximal inhibitory concentration: 12600 nM
The estimate for compound 4 lay 1.4-fold (0.15 log units) above the measured number, and the stated range covers the measured number.
By their numbers in this assay, from the lowest: compounds 4, 3, 1 and 2 (each within the scatter of the next).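

In this assay, the exchange of pyridin-2-yl for pyridin-3-yl, which keeps the same atoms but joins them differently, gives a 1.2-fold lower number from compound 3 to compound 4 (0.08 log units; within the scatter) and so does not separate these two pyridine isomers at this position. The same holds against the five-membered rings, with a 1.9-fold lower number from compound 2 to compound 4 (0.28 log units; within the scatter) and a 1.5-fold lower number from compound 1 to compound 4 (0.18 log units; within the scatter), so the tolerance seen among thiophen-2-yl, furan-2-yl and pyridin-2-yl now extends to a fourth aromatic group, and no step among these compounds leaves the scatter. No measured evidence accounts for this flat response.

As far as these compounds go, all four compounds carry an unsubstituted aromatic ring at this position, so it stays open whether pyridin-4-yl, a ring bearing an amine or a carboxylic acid, or a saturated group such as morpholine or a longer alkyl chain would move the number beyond the scatter. From the compounds shown here alone, the 3-hydroxyphenyl and phenyl groups are the same throughout, so what they contribute to the values in this assay also remains open.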